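Swapping the Sulfonylpiperazine of Compound 2 for a Hydroxypiperidine

A few compounds are considered here, and "the series" means these few. Any claim that something is new, unique, unknown or untested is made for them only; others in the source may bear on it.

In a functional assay on CHO-K1 cells for antagonist activity at melanin-concentrating hormone receptor 1 (Homo sapiens), read by inositol phosphate accumulation (a lower number here means a stronger inhibitor, a higher number a weaker inhibitor), compound 1 `Cc1nc(N2CCN(C3CCOCC3)CC2)nc2ccc(NC(=O)COc3ccc(Cl)cc3)cc12` gives 115 nM. Compound 2 `Cc1nc(N2CCN(S(C)(=O)=O)CC2)nc2ccc(NC(=O)COc3ccc(Cl)cc3)cc12` reaches only the limit of this assay, > 10000 nM. Compound 3 `Cc1nc(N2CCC(O)CC2)nc2ccc(NC(=O)C(C)(C)Oc3ccc(Cl)cc3)cc12` also sits at a limit, > 10000 nM. Among the compounds with values here, the single measured step, an at least 86-fold higher number from compound 1 to compound 2 (1.93 log units; beyond the scatter), is the only direct guide, and the limit of > 10000 nM in this assay, at which 2 of the 3 values shown sit, shows how far compound 2 and compound 3 lie from compound 1. Compound 4 `CCC1(O)CCN(c2nc(C)c3cc(NC(=O)COc4ccc(Cl)cc4)ccc3n2)CC1` carries 4-ethyl-4-hydroxypiperidin-1-yl in place of 4-(methylsulfonyl)piperazin-1-yl on an aromatic carbon. The change removes the methylsulfonyl group that accompanied the loss seen in an at least 86-fold higher number from compound 1 to compound 2 (1.93 log units; beyond the scatter), while compound 3, bearing a hydroxypiperidine with a different amide, stayed at the limit. Compound 4 is therefore expected to improve by roughly an at least 10-fold lower number from compound 2 to compound 4 (1.00 log units; beyond the scatter) in this assay. The estimate for compound 4 is 1000 nM, spanning 150 nM to 10000 nM.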

Compound 4, half-maximal inhibitory concentration: 384 nM
Beside the measured number, compound 4's estimate is 2.6-fold (0.42 log units) above it; the measured number falls inside the stated range.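

In this assay, 4-ethyl-4-hydroxypiperidin-1-yl in place of 4-(methylsulfonyl)piperazin-1-yl gives an at least 26-fold lower number from compound 2 to compound 4 (1.41 log units; beyond the scatter). On this aromatic carbon between two ring nitrogen atoms, then, a measurable value does not depend on a piperazine, which compound 1 alone could not show. The step starts from a limit of compound 2, not a number: the limit of > 10000 nM in this assay, at which 2 of the 4 values shown sit.

Going by these compounds, whether the hydroxyl or the ethyl group carries the step remains open, as does how a 4-aminopiperidin-1-yl group would read at this carbon. Compound 3 differs from compound 4 in more than one place, so its limit settles neither question.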